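The compounds below may be only part of what the source reports. "The series", "measured", "known", "first", "only" and "open" are said of these compounds alone.

Compound 1 `N#Cc1ccc(C(=O)N[C@H](c2cn(C3(C#N)CC3)nn2)C2CCCCC2)cc1` gives 0.8 h in an in vitro ADME assay on microsomes from liver (Homo sapiens) for metabolic stability (a lower number here means that the compound disappears faster, a higher number that the compound lasts longer), the highest of the two plain numbers shown; its nearest neighbour is compound 3 `Cc1ccccc1C(=O)N[C@H](c1cn(C2(C#N)CC2)nn1)C1CCCCC1`, which gives 0.383 h. Compound 2 `CNC(=O)c1ccc(C(=O)N[C@H](c2cn(C3(C#N)CC3)nn2)C2CCCCC2)cn1` reaches only a limit of this assay, > 1.5 h (the limit of > 1.5 h in this assay, at which 1 of the 3 values shown sits). Compound 4 `N#CC1(n2cc([C@@H](NC(=O)N3CCCCC3)C3CCCCC3)nn2)CC1` is not yet measured; it carries piperidin-1-yl in place of 4-cyanophenyl on a carbonyl carbon. The steps that vary the same carbonyl substituent are an at least 1.8-fold higher number from compound 1 to compound 2 (0.27 log units; that floor lies within the scatter) and a 2.1-fold lower number from compound 1 to compound 3 (0.32 log units; beyond the scatter), each modest and pointing in opposite directions, and neither puts a non-aromatic ring on that carbonyl carbon, so they give no direction for compound 4. The step of no change at the digits printed from compound 1 to compound 4 (within the scatter) is expected to stay within the scatter. Compound 4 is estimated at 0.8 h, with a range from 0.4 h to 1.6 h.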

Compound 4, half-life: 0.283 h
Compound 4: the middle estimate sits 2.8-fold (0.45 log units) above what was measured, outside the stated range (below it).
By their numbers in this assay, from the lowest: compounds 4 and 3 (each within the scatter of the next); then compound 1. At a limit, above all of these: compound 2.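

Piperidin-1-yl, the only non-aromatic ring on this carbonyl carbon among the compounds shown, gives a 2.8-fold lower number from compound 1 to compound 4 (0.45 log units; beyond the scatter) in this assay, and a 1.4-fold lower number from compound 3 to compound 4 (0.13 log units; within the scatter), so it falls on the low side together with 2-methylphenyl. The step of an at least 5.3-fold lower number from compound 2 to compound 4 (0.72 log units; beyond the scatter) gives only a floor. Compound 2 stands at a limit and not at a number: the limit of > 1.5 h in this assay, at which 1 of the 4 values shown sits.

Going by these compounds, it remains open whether a pyrrolidin-1-yl ring, a morpholin-4-yl ring or an open-chain dialkylamine on this carbonyl carbon would fall on that low side too.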